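Aryl swap on the piperazine series, cytotoxicity toward MCF7 cells

The source may hold more compounds than are shown below. What is called first, only, known or untested is meant among the compounds shown, and "the series" means these compounds.

Measured so far:
compound 1, `COc1ccc(N2CCN(CCCSc3nc4ccccc4[nH]3)CC2)cc1`, 6840 nM
compound 2, `CCOc1ccccc1N1CCN(CCCSc2nc3cc(Cl)ccc3[nH]2)CC1`, 27700 nM

Two compounds of the series have numbers in a functional assay on MCF7 cells (Homo sapiens) for cytotoxicity, read by MTT assay, with a stated time of 24 h; a higher number here means a weaker inhibitor, a lower number a stronger inhibitor. Compound 1, `COc1ccc(N2CCN(CCCSc3nc4ccccc4[nH]3)CC2)cc1`, gives 6840 nM in this assay. Compound 2, `CCOc1ccccc1N1CCN(CCCSc2nc3cc(Cl)ccc3[nH]2)CC1`, gives 27700 nM in this assay, the highest of the two numbers, and its gap to compound 1 lies beyond the scatter. Compound 1 and compound 2 differ in two places at once, so their two values alone say nothing about either change on its own.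

Compound 3, `COc1ccc(N2CCN(CCCSc3nc4cc(Cl)ccc4[nH]3)CC2)cc1`, is not yet measured. It differs from compound 2 in one place: 4-methoxyphenyl in place of 2-ethoxyphenyl on an amine nitrogen in a ring. Compound 3 thus carries the aryl group of compound 1 on the core of compound 2. Among the measured compounds shown here, no step between measured compounds isolates this change. Since compound 1 gives 6840 nM with the same aryl group, a step downward from compound 2 to compound 3 in this assay is expected, of moderate size, though the chlorine left in place could also carry part of the gap. The expected step is a 2.3-fold lower number from compound 2 to compound 3 (0.36 log units; beyond the scatter). Compound 3 is estimated at 12000 nM in this assay, within 4000 nM to 35000 nM.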

Compound 3, half-maximal inhibitory concentration: 38500 nM
For compound 3 the middle estimate is 3.2-fold (0.51 log units) below the measured one; measured number above the stated range.
By their numbers in this assay, from the lowest: compound 1; then compounds 2 and 3 (each within the scatter of the next).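

In this assay, 4-methoxyphenyl in place of 2-ethoxyphenyl on an amine nitrogen in a ring gives a 1.4-fold higher number from compound 2 to compound 3 (0.14 log units; within the scatter), so with the chlorine in place these two aryl groups cannot be told apart at this position. Chloro in place of hydrogen on an aromatic carbon, read with 4-methoxyphenyl held constant, gives a 5.6-fold higher number from compound 1 to compound 3 (0.75 log units; beyond the scatter), the first single-change step in the series to lie beyond the scatter and a loss of cytotoxic strength for this pair. No measurement shown here accounts for either step.

As far as these compounds go, it remains open whether the chloro step also holds with 2-ethoxyphenyl on the piperazine nitrogen, and whether the two aryl groups would still be indistinguishable on the core without chlorine. Also open, from the compounds shown here alone, is how a different group on that aromatic carbon, such as a nitrile or a carboxylic acid, or a phenyl ring bearing an amine in place of the alkoxy group, would read in this assay.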